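Urea aryl swap on two pyridine cores

This account rests on a few compounds, and the source may have more. Where it says the series, first, only, none or still open, it means among the compounds named here.

Compound 1 `CCNc1cc(-c2ccc(NC(=O)Nc3cccc(Cl)c3)cc2F)ccn1` and compound 2 `CCNc1cc(-c2ccc(NC(=O)Nc3ccc(C(F)(F)F)cc3)cc2F)ccn1` share one core; compound 3 `CCCNc1cc(-c2ccc(NC(=O)Nc3cccc(Cl)c3)cc2C(F)(F)F)ccn1` and compound 4 `CCCNc1cc(-c2ccc(NC(=O)Nc3ccc(C(F)(F)F)cc3)cc2C(F)(F)F)ccn1` share another, and the difference between the two cores is not broken down here. In an assay on isolated protein for inhibition of serine/threonine-protein kinase PLK1 (Homo sapiens), read by radiometric assay and 33P incorporation, with a stated time of 40 min, tested at 20 uM, in the presence of a further agent that is not named here (a lower number here means less inhibition, a higher number more inhibition at the concentration tested (going by the name of the read-out)), compound 1 gives 72.7% and compound 2 gives 55.8%; the change 4-(trifluoromethyl)phenyl in place of 3-chlorophenyl on an amide-type nitrogen made a step of a number 16.9 percentage points lower from compound 1 to compound 2 (beyond the scatter). Compound 3 gives 63% in this assay. The change from compound 3 to compound 4 is the same change at the same place: 4-(trifluoromethyl)phenyl in place of 3-chlorophenyl on an amide-type nitrogen. For the measured compounds named here, on the expectation that the step repeats in size, compound 4 is estimated at 46% in this assay, a step of a number 17 percentage points lower from compound 3 to compound 4 (beyond the scatter), with a range from 30% to 60%, because a number 16.9 percentage points lower from compound 1 to compound 2 (beyond the scatter) is the only measured step that carries this change.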

Compound 4, a percentage reported as inhibition, at one concentration (the size of the read-out at that concentration, not a potency): 51.3%
Beside the measured number, compound 4's estimate is 5.3 percentage points below it, and the stated range covers the measured number.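

With 4-(trifluoromethyl)phenyl in place of 3-chlorophenyl on the amide-type nitrogen, this assay gives a number 11.7 percentage points lower from compound 3 to compound 4 (beyond the scatter) on the second core, so the change lowers the reading on both cores shown. Two pairs support no more than that: they say nothing about other cores, and readings at one concentration are not potencies. As far as these pairs can tell, the size of the step carries over from one core to the other: the same change on two cores in this assay, a number 16.9 percentage points lower (beyond the scatter) from compound 1 to compound 2 and a number 11.7 percentage points lower (beyond the scatter) from compound 3 to compound 4, 5.2 percentage points apart, within the scatter of two such steps

Still open is whether 4-chlorophenyl or 3-(trifluoromethyl)phenyl on the same nitrogen would read like the two groups shown. Also open, as far as these compounds go, is whether the step would hold on a core with a butyl chain in place of the ethyl or propyl chain.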